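Bromo to chloro swap: from compound 2 to compound 4

The source may hold more compounds than are shown below. What is called first, only, known or untested is meant among the compounds shown, and "the series" means these compounds.

Measured so far:
compound 1 `Cc1nc(N)sc1CCCN/C(N)=N/C(=O)N[C@H](C)c1ccccc1` — 17.8 nM
compound 2 `Cc1nc(N)sc1CCCN/C(N)=N/C(=O)NC(C)c1ccc(Br)cc1` — 30.2 nM
compound 3 `Cc1nc(N)sc1CCCN/C(N)=N/C(=O)NC(c1ccccc1)c1ccccc1` — 43.7 nM

All three values come from an assay on membranes from Sf9 cells for displacement of a labelled ligand from histamine H2 receptor (Homo sapiens), read by scintillation counting, with a stated time of 60 min; on this read-out higher numbers stand for weaker inhibition and lower numbers for stronger inhibition. Compound 2 stands second highest of the three numbers. Its nearest neighbour is compound 3, whose number is higher, and its furthest is compound 1, whose number is lower; both gaps lie within the scatter of the method, so nothing can be read as an order among the three, and none of them can be called stronger or weaker than another.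

Compound 4 `Cc1nc(N)sc1CCCN/C(N)=N/C(=O)NC(C)c1ccc(Cl)cc1` is not yet measured. Against compound 2 the change is chloro in place of bromo on an aromatic carbon, para to a large group, so that a 4-bromophenyl becomes a 4-chlorophenyl. Among the compounds with values here, no pair of measured compounds shows this exchange, so no measured step is available to lean on. With three numbers that all sit within the scatter of one another, and a change that keeps the count of heavy atoms, donors, acceptors and charge unchanged, the expectation is a step from compound 2 to compound 4 of no size beyond the scatter, a 1.0-fold lower number from compound 2 to compound 4 (0.00 log units; within the scatter). The estimate for compound 4 in this assay is therefore 30 nM, expected between 14 nM and 65 nM.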

Compound 4, inhibition constant: 46.8 nM
The estimate for compound 4 lay 1.6-fold (0.19 log units) below the measured number, within the range that was stated.
By their numbers in this assay, from the lowest: compounds 1, 2, 3 and 4 (each within the scatter of the next, the first and the last beyond it).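

In this assay, within the data shown here, the change from 4-bromophenyl to 4-chlorophenyl supplies the first step between two compounds that differ in one place: a 1.5-fold higher number from compound 2 to compound 4 (0.19 log units; within the scatter). Among these compounds, for this pair, chloro in place of bromo on an aromatic carbon, para to a large group, therefore gives no difference that can be told apart from the scatter, which the earlier compounds, lacking any such pair, could not show. Nothing measured here bears on what lies behind this step.

As far as these compounds go, what stays open is whether groups other than these two halogens, such as fluoro, methoxy, an amine or a carboxylic acid, on the same aromatic carbon would keep the number within the scatter of compound 2. Among the compounds shown here, it is also open whether the same exchange of bromo for chloro would stay within the scatter on a compound with a longer chain in the shared core, as this single pair is the only record of the change.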